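Methyl for methoxy on the five-membered ring of compound 1

The compounds below may be only part of what the source reports. "The series", "measured", "known", "first", "only" and "open" are said of these compounds alone.

Compound 1 `CCCC(Oc1ccc(-n2cc(OC)cn2)cc1)c1ccc(C(=O)NCCC(=O)O)cc1` gives 4400 nM in an assay on cells for displacement of a labelled ligand from Glucagon receptor (Homo sapiens), in the presence of a further agent that is not named here (a lower number here means a stronger inhibitor, a higher number a weaker inhibitor), the highest number of the three measured compounds. Compound 2 `O=C(O)CCNC(=O)c1ccc(C(Oc2ccc(-n3cc(C(F)(F)F)cn3)cc2)C2CC2)cc1` gives 1300 nM in this assay, and compound 3 `CCCC(Oc1ccc(-n2cc3ccccc3n2)cc1)c1ccc(C(=O)NCCC(=O)O)cc1` gives 290 nM in this assay. For the measured compounds named here, compound 2 differs from compound 1 in two places, so the two values show only that compound 2 sits lower. Going by the values given here, the single one-place step is a 15-fold lower number from compound 1 to compound 3 (1.18 log units; beyond the scatter), a large change at the five-membered aromatic ring with 2 nitrogen. Compound 4 `CCCC(Oc1ccc(-n2cc(C)cn2)cc1)c1ccc(C(=O)NCCC(=O)O)cc1` differs from compound 1 by methyl in place of methoxy on an aromatic carbon. Among the compounds with values here, no measured step covers methoxy against methyl; the step from compound 1 to compound 3 shows that this ring can move the number a great deal, but it exchanges the whole ring and gives no direction for a smaller change. A small step is therefore expected, near the scatter, with the direction open; the expected step is a 1.4-fold lower number from compound 1 to compound 4 (0.14 log units; within the scatter). Compound 4 is estimated at 3200 nM in this assay, within a range of 1200 nM to 8500 nM.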

Compound 4, inhibition constant: 1900 nM
The estimate for compound 4 lay 1.7-fold (0.23 log units) above the measured number; low and high end bracket the measured number.
By their numbers in this assay, from the lowest: compound 3; then compounds 2 and 4 (each within the scatter of the next); then compound 1.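

In this assay, exchanging methoxy for methyl on this aromatic carbon gives a 2.3-fold lower number from compound 1 to compound 4 (0.36 log units; beyond the scatter), so a single small substituent on the five-membered aromatic ring with 2 nitrogen moves the number beyond the scatter, which the whole-ring exchange could not show. Replacing the ring remains the larger change, at a 6.6-fold higher number from compound 3 to compound 4 (0.82 log units; beyond the scatter), and 2H-indazol-2-yl keeps its lead over 4-methyl-1H-pyrazol-1-yl. Nothing on hand explains the methyl step, and the lost oxygen and the lost hydrogen-bond acceptor cannot be separated from the loss of a heavy atom.

Open, going by these compounds, is how a nitrile, a chlorine atom or a longer chain such as ethyl on this aromatic carbon would compare with methyl and methoxy. Also open, on these data alone, is whether the methyl step carries over to the core of compound 2.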